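Swapping Chloro for Trifluoromethyl on a Growth Inhibitor

This account rests on a few compounds, and the source may have more. Where it says the series, first, only, none or still open, it means among the compounds named here.

In a functional assay on IGROV-1 cells (Homo sapiens) for inhibition, read by sulforhodamine B assay, with a stated time of 48 h (on this read-out higher numbers stand for weaker inhibition of growth and lower numbers for stronger inhibition of growth), compound 1 `COc1cc(-c2nn(-c3cccc(NC(=O)Nc4ccc(Cl)c(Cl)c4)c3)cc2-c2ccncc2)ccc1Cl` gives 1180 nM and compound 2 `O=C(Nc1cccc(-n2cc(-c3ccncc3)c(-c3ccc(Cl)c(O)c3)n2)c1)Nc1ccc(Cl)c(Cl)c1` gives 1770 nM in the same test. These two numbers lie within the usual scatter of each other, so compound 2 cannot be ranked against compound 1.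

Compound 3 `O=C(Nc1cccc(-n2cc(-c3ccncc3)c(-c3ccc(Cl)c(O)c3)n2)c1)Nc1ccc(Cl)c(C(F)(F)F)c1` differs from compound 2 in one group, with trifluoromethyl in place of chloro on an aromatic carbon. This turns 3,4-dichlorophenyl into 4-chloro-3-(trifluoromethyl)phenyl, and the new group sits ortho to a chloro group.

Among the measured compounds shown here, only one measured step exists (a 1.5-fold higher number from compound 1 to compound 2 (0.18 log units; within the scatter)), and it is a different change, hydrogen in place of methyl on an oxygen on an aromatic ring. It stayed within the scatter, but it says nothing direct about swapping chloro for trifluoromethyl. With no measured guide to this swap, no shift beyond the scatter is expected in either direction in this assay on this evidence.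

The estimated change is a 1.2-fold lower number from compound 2 to compound 3 (0.07 log units; within the scatter) and would stay within the scatter. For compound 3 the estimated value is 1500 nM with an expected range from 600 nM to 3800 nM in this test.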

Compound 3, concentration for 50% growth inhibition: 715 nM
Compound 3: the middle estimate sits 2.1-fold (0.32 log units) above what was measured; the range from low to high includes it.
By their numbers in this assay, from the lowest: compounds 3, 1 and 2 (each within the scatter of the next, the first and the last beyond it).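

Among the compounds shown here, the step of a 2.5-fold lower number from compound 2 to compound 3 (0.39 log units; beyond the scatter) is the first one here to go beyond the scatter in this assay, which shows that the group on this aromatic carbon, ortho to a chloro group, can change the result, whereas the earlier step between compound 1 and compound 2, at a different place, could not be told from scatter. The swap replaces chloro, with 1 heavy atom, by trifluoromethyl, with 4, adds no hydrogen-bond donors or acceptors and no net charge, and moves the number modestly towards stronger inhibition of growth. Nothing in the data shown gives a measured reason for this shift, so the step stands as an observation rather than an explanation.

The compounds shown leave open how other groups in the same place, such as a nitrile, a bromo group or a methyl group, would compare with chloro and trifluoromethyl. They also leave open whether the same swap would give a similar step in the series with a methoxy group, as in compound 1, rather than the hydroxyl group of compound 2 and compound 3.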